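Chain extension on the core: propyl to butyl

The source may hold more compounds than are shown below. What is called first, only, known or untested is meant among the compounds shown, and "the series" means these compounds.

Compound 3 `CCCc1cc2ccccc2nc1-c1cn(-c2ccc(F)cc2)nn1` gives 67.4 ug/mL in a functional assay on U-937 cells (Homo sapiens) for cytotoxicity, read by MTT assay, with a stated time of 24 h (a lower number here means a stronger inhibitor, a higher number a weaker inhibitor), and holds the lowest of the two numbers in hand. Compound 1 `CCCCCc1cc2ccccc2nc1-c1cn(-c2ccc(F)cc2)nn1` gives 67.5 ug/mL in this assay, the step being a 1.0-fold lower number from compound 1 to compound 3 (0.00 log units; within the scatter). Compound 2 `CCc1cc2ccccc2nc1-c1cn(-c2ccc(F)cc2)nn1` returns only a limit in this assay, > 100 ug/mL. One of the three results is therefore such a limit (the limit of > 100 ug/mL in this assay, at which 1 of the 3 values shown sits).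

Compound 4 `CCCCc1cc2ccccc2nc1-c1cn(-c2ccc(F)cc2)nn1` differs from compound 3 by methyl in place of hydrogen on a saturated chain carbon, three bonds along the chain from an aromatic carbon. The measured step at the same place is a 1.0-fold lower number from compound 1 to compound 3 (0.00 log units; within the scatter), where hydrogen in place of ethyl three bonds along the chain left the number unchanged. The steps nearer the aromatic carbon, an at least 1.4-fold higher number from compound 1 to compound 2 (0.17 log units; that floor lies within the scatter) and an at least 1.4-fold lower number from compound 2 to compound 3 (0.17 log units; that floor lies within the scatter), only reach the floor set by the limit of compound 2 and so give no direction beyond the scatter either. For compound 4 a step of a 1.0-fold lower number from compound 3 to compound 4 (0.02 log units; within the scatter) in this assay is expected, that is none beyond the scatter. Compound 4 is estimated at 65 ug/mL, with a range from 35 ug/mL to 100 ug/mL.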

Compound 4, half-maximal inhibitory concentration: 66.2 ug/mL
Beside the measured number, compound 4's estimate is 1.0-fold (0.01 log units) below it; the measured number falls inside the stated range.
By their numbers in this assay, from the lowest: compounds 4, 3 and 1 (each within the scatter of the next). At a limit, above all of these: compound 2.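

Butyl fills the gap between propyl and pentyl, and in this assay the three chains cannot be told apart: a 1.0-fold lower number from compound 3 to compound 4 (0.01 log units; within the scatter), and a 1.0-fold lower number from compound 1 to compound 4 (0.01 log units; within the scatter). The added methyl, three bonds along the chain from an aromatic carbon, therefore leaves no mark beyond the scatter, and the same holds for the further carbon of the pentyl chain. Against the ethyl chain there is only a floor, an at least 1.5-fold lower number from compound 2 to compound 4 (0.17 log units; that floor lies within the scatter), and compound 2 gives > 100 ug/mL, which is a limit, so whether the same change behaves alike on the two cores stays unsettled: the same change on two cores in this assay, a 1.0-fold lower number (0.00 log units; within the scatter) from compound 1 to compound 3 and an at least 1.5-fold higher number (0.17 log units; that floor lies within the scatter) from compound 4 to compound 2; the limit leaves it open whether they differ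

Going by these compounds, whether the numbers stay within the scatter beyond pentyl, with a longer chain such as octyl, remains open. So does whether a terminal amine or a carboxylic acid on the chain would move the number beyond the scatter.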